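Triazole aryl swap on the furanone series: compound 4

The source may report more compounds than this note shows. Statements on the series, on what has been measured and on what is new or still open speak of the compounds shown alone.

The shared core of compound 1 `Cc1ccc(S(=O)(=O)NCc2cn(C[C@H](O)[C@H]3OC(=O)C(OCc4ccccc4)=C3OCc3ccccc3)nn2)cc1` carries a (((4-methylphenyl)sulfonyl)amino)methyl group on the five-membered ring with three nitrogens. In a functional assay on CFPAC-1 cells (Homo sapiens) for antiproliferative activity, read by MTT assay, with a stated time of 72 h (a higher number here means a weaker inhibitor, a lower number a stronger inhibitor), compound 1 gives 68000 nM. Compound 3 `COc1ccccc1-c1cn(C[C@H](O)[C@H]2OC(=O)C(OCc3ccccc3)=C2OCc2ccccc2)nn1` carries 2-methoxyphenyl in that position. In this assay compound 3 reaches only the limit of the assay, > 100000 nM, not a number. The step of an at least 1.4-fold higher number from compound 1 to compound 3 (0.16 log units; that floor lies within the scatter) is therefore itself only a floor, and the limit of > 100000 nM in this assay, at which 1 of the 3 values shown sits, marks that one value of the three sits at this limit. Compound 2 `O=C1O/C(=C\Cn2cc(-c3cc(F)cc(F)c3)nn2)C(OCc2ccccc2)=C1OCc1ccccc1` differs from these two in the linker to the core and carries 3,5-difluorophenyl; in this assay compound 2 is reported as "not active" (no number reported), so it stands without a number, at the weak end of what is shown.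

Compound 4 `O=C1O/C(=C\Cn2cc(-c3cccc(O)c3)nn2)C(OCc2ccccc2)=C1OCc1ccccc1` is compound 2 with 3-hydroxyphenyl in place of 3,5-difluorophenyl on an aromatic carbon. Within the data shown here, no measured step covers this exchange; the single measured step concerns a different pair of groups and is a floor that lies within the scatter. All three measured values sit at or beyond the weak end, so for compound 4 in this assay no shift beyond the scatter is expected, and the reading is expected to remain weak or to come back as a limit. The estimate for compound 4 is 80000 nM, with a range from 30000 nM to 200000 nM.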

Compound 4, half-maximal inhibitory concentration: 33700 nM
Beside the measured number, compound 4's estimate is 2.4-fold (0.38 log units) above it, and the stated range covers the measured number.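

No step can be read between compound 2 and compound 4: in this assay compound 2 is reported as "not active", with no number, while compound 4 gives 33700 nM. The compounds shown leave open how much 3-hydroxyphenyl in place of 3,5-difluorophenyl shifts the reading on this linker.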